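Replacing methoxy with chloro in compound 3

This account rests on a few compounds, and the source may have more. Where it says the series, first, only, none or still open, it means among the compounds named here.

In a functional assay on cells (Homo sapiens) for antiproliferative activity, read by CellTiter-Glo, with a stated time of 96 h (a lower number here means a stronger inhibitor, a higher number a weaker inhibitor), compound 1 (`COc1ccc(-c2nsc3c2NC(=O)CC3c2cccc(OC)c2)cc1`) gives 1910 nM as a measured number. Compound 2 (`COc1ccc(-c2nsc3c2NC(=O)CC3c2cccc(Cl)c2)cc1`) reads > 2000 nM and that is a limit of the assay. Compound 3 (`COc1ccc(-c2nsc3c2NC(=O)CC3c2ccsc2)cc1`) gives 309 nM as the lowest number shown, and a 6.2-fold lower number from compound 1 to compound 3 (0.79 log units; beyond the scatter) separates it from its nearest measured neighbour. Compound 4 (`O=C1CC(c2ccsc2)c2snc(-c3ccc(Cl)cc3)c2N1`) differs from compound 3 in one place: chloro in place of methoxy on an aromatic carbon with chloro in place of methoxy. The same swap appears in an at least 1.0-fold higher number from compound 1 to compound 2 (0.01 log units; that floor lies within the scatter) but elsewhere in the molecule and against a limit, so it gives only weak guidance. No step beyond the scatter is therefore expected, and the estimate is a 1.5-fold higher number from compound 3 to compound 4 (0.16 log units; within the scatter) in this comparison. Compound 4 is expected at 450 nM within an estimated range of 130 nM to 1600 nM in this assay once measured.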

Compound 4, half-maximal inhibitory concentration: > 2000 nM
Compound 4: a limit, no number (the forecaster's own chance of this, stated with the estimate: 10%); middle value at least 4.4-fold (0.64 log units) away from the limit.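

With the thiophen-3-yl group on the core, methoxy at this place para to a large group cannot be exchanged for chloro without loss: in this assay the swap gives an at least 6.4-fold higher number from compound 3 to compound 4 (0.81 log units; beyond the scatter). Compound 4 reads > 2000 nM, which is a limit of the assay, so this step is only a floor. The earlier pair showed no step beyond the scatter, and the two cores cannot yet be told apart: the same change on two cores in this assay, an at least 1.0-fold higher number (0.01 log units; that floor lies within the scatter) from compound 1 to compound 2 and an at least 6.4-fold higher number (0.81 log units; beyond the scatter) from compound 3 to compound 4; the limit leaves it open whether they differ

The compounds shown leave open whether a hydroxyl, an amine or a fluoro at this place would hold the number of compound 3.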